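A few compounds are considered here, and "the series" means these few. Any claim that something is new, unique, unknown or untested is made for them only; others in the source may bear on it.

Within the data shown here, compound 1 `COc1cc2c(/C=C3/C(=O)Nc4ccc(O)cc43)c(Cl)n(Cc3cc(OC)c(OC)c(OC)c3)c2cc1C` is the weakest inhibitor among the three compounds measured so far: in a functional assay on cells (Cancer cell lines, Homo sapiens) for cytotoxicity, with a stated time of 48 h (on this read-out higher numbers stand for weaker inhibition of growth and lower numbers for stronger inhibition of growth), compound 1 gives 2750 nM. Compound 3 `COc1ccc2c(c1)/C(=C\c1c(Cl)n(C/C=C/c3ccccc3)c3ccccc13)C(=O)N2` comes closest, giving 1910 nM in this assay, a gap that lies within the usual scatter. Compound 2 `COc1c(/C=C2/C(=O)Nc3ccccc32)c2ccccc2n1-c1ccccc1` sits furthest away, giving 1120 nM, a gap that does lie beyond the scatter.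

Compound 4 `COc1ccc2c(c1)/C(=C\c1c(Cl)n(Cc3cc(OC)c(OC)c(OC)c3)c3cc(C)c(OC)cc13)C(=O)N2` differs from compound 1 in a single place: methyl in place of hydrogen on an oxygen on an aromatic ring. No matching change between two measured compounds is available for comparison, so the direction of any step cannot be read from the data. The change is expected to make little difference, with a step from compound 1 to compound 4 of a 1.4-fold lower number from compound 1 to compound 4 (0.14 log units; within the scatter), no larger than the scatter. Compound 4 is accordingly estimated at 2000 nM, with a likely range from 900 nM to 5000 nM.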

Compound 4, concentration for 50% growth inhibition: 29500 nM
The estimate for compound 4 lay 15-fold (1.17 log units) below the measured number; the whole stated range lies below it.
By their numbers in this assay, from the lowest: compounds 2, 3 and 1 (each within the scatter of the next, the first and the last beyond it); then compound 4.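

Capping the hydroxy group as methoxy adds only one carbon, yet it brings an 11-fold higher number from compound 1 to compound 4 (1.03 log units; beyond the scatter) in this assay and so much weaker inhibition of growth. This oxygen on an aromatic ring is therefore a sensitive place, where a very small edit can matter greatly, although that rests on this single pair. Nothing available explains why the step is so large.

As far as these compounds go, how an amine or a longer chain such as ethoxy would fare at this place remains open. So does whether the same change would cost as much on a different compound.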